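A few compounds are considered here, and "the series" means these few. Any claim that something is new, unique, unknown or untested is made for them only; others in the source may bear on it.

Among the compounds with values here, in a functional assay on WHCO1 cells (Homo sapiens) for cytotoxicity, read by MTT assay, with a stated time of 24 h (a higher number here means a weaker inhibitor, a lower number a stronger inhibitor), compound 2 `O=C1C=C(C(O)c2ccccc2)C(=O)c2ccccc21` gives 3900 nM, the second highest of the three numbers so far. Its nearest neighbour is compound 1 `O=C1C=C([C@@H](O)c2ccccc2)C(=O)c2ccccc21`, which in this assay gives 3800 nM, the step being a 1.0-fold higher number from compound 1 to compound 2 (0.01 log units; within the scatter). The furthest is compound 3 `O=C1C=C([C@H](O)c2ccccc2)C(=O)c2ccccc21`, which in this assay gives 4300 nM, with a 1.1-fold higher number from compound 2 to compound 3 (0.04 log units; within the scatter) and a 1.1-fold higher number from compound 1 to compound 3 (0.05 log units; within the scatter). Compound 4 `O=C1C=C(C(O)c2cccc(Cl)c2)C(=O)c2ccccc21` differs from compound 2 by chloro in place of hydrogen on an aromatic carbon. None of the three measured steps touches the phenyl group; each only alters the drawn configuration of the carbinol centre (the fact that compounds 1 and 3 differ only in the configuration as drawn), and all sit within the scatter, so they give no guidance on a chloro substituent. The step to compound 4 is therefore expected to be no change at the digits printed from compound 2 to compound 4 (within the scatter), with no direction beyond the scatter. Compound 4 is estimated at 3900 nM, between 1300 nM and 12000 nM.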

Compound 4, half-maximal inhibitory concentration: 7300 nM
The estimate for compound 4 lay 1.9-fold (0.27 log units) below the measured number; low and high end bracket the measured number.
By their numbers in this assay, from the lowest: compounds 1, 2, 3 and 4 (each within the scatter of the next).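

With a 1.9-fold higher number from compound 2 to compound 4 (0.27 log units; within the scatter) in this assay for chloro in place of hydrogen, this is the first change shown on the phenyl group rather than at the carbinol centre. It shows that a chloro at this place on the phenyl group leaves the number within the scatter, as the changes in drawn configuration did. Nothing available bears on the effect of this chloro.

As far as these compounds go, whether an amine, a methoxy group or a carboxylic acid at this place would give a step beyond the scatter stays open. So does whether the configuration of the carbinol centre matters once the chloro is present.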